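The source may report more compounds than this note shows. Statements on the series, on what has been measured and on what is new or still open speak of the compounds shown alone.

Three related esters were examined in a functional assay on EA.hy 926 cells (Homo sapiens) for cytotoxicity, read by MTT assay, with stated times of 24 h and 12 h, tested at 12.5 uM; a lower number here means a weaker effect, a higher number a stronger effect of the compound at the concentration tested. Compound 1 `COc1ccc(/C=C/C(=O)O)c(OC(=O)c2nc(C)c(C)nc2C)c1` gives 39.7% in this assay. Compound 2 `CCOC(=O)/C=C/c1ccc(OC)cc1OC(=O)c1nc(C)c(C)nc1C` gives -57.6% in this assay, and the step of a number 97.3 percentage points lower from compound 1 to compound 2 (beyond the scatter) goes with the change (ethyl in place of hydrogen on an oxygen next to a carbonyl group). Compound 3 `COc1ccc(/C=C/C(=O)O)cc1OC(=O)c1nc(C)c(C)nc1C` gives 41.3% in this assay; its value and that of compound 1 lie within the scatter of each other, while compound 2 lies far below both. The cores of compound 3 and compound 1 are built from the same atoms joined differently, and that difference is not broken down here. Compound 4 `CCOC(=O)/C=C/c1ccc(OC)c(OC(=O)c2nc(C)c(C)nc2C)c1` has not yet been measured. It differs from compound 3 by ethyl in place of hydrogen on an oxygen next to a carbonyl group, the same change as from compound 1 to compound 2, made at the same place, so that this change occurs twice among these compounds. Because that change gave a number 97.3 percentage points lower from compound 1 to compound 2 (beyond the scatter), a step of similar size is expected now, a number 91.3 percentage points lower from compound 3 to compound 4 (beyond the scatter). Compound 4 is accordingly estimated at -50%, between -85% and -10%. Among the compounds with values here, only one earlier step guides this expectation, so the range is kept wide.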

Compound 4, a percentage reported as activity, at one concentration (the size of the read-out at that concentration, not a potency): 26.4%
Beside the measured number, compound 4's estimate is 76.4 percentage points below it; the measured number lies above the stated range.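

In this assay, ethyl in place of hydrogen on an oxygen next to a carbonyl group gave a number 14.9 percentage points lower from compound 3 to compound 4 (beyond the scatter) and so kept the direction seen on the other core, but not the size. Set side by side, the two steps do not agree: the same change on two cores in this assay, a number 97.3 percentage points lower (beyond the scatter) from compound 1 to compound 2 and a number 14.9 percentage points lower (beyond the scatter) from compound 3 to compound 4, 82.4 percentage points apart, beyond the scatter of two such steps.

This shows that, in this series, the size of the step from carboxy to ethoxycarbonyl on the core of compound 1 cannot simply be carried over to the core of compound 3, whereas it does not show what in the two cores separates the steps, and two pairs cannot establish that the direction would hold on any further core.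

The compounds shown leave open how a methyl ester or a longer chain in place of ethyl would behave on either core. They also leave open whether an amide in place of the ester would follow the ethyl ester or the carboxylic acid, and whether it would separate the two cores to the same extent.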